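The compounds below may be only part of what the source reports. "The series", "measured", "known", "first", "only" and "open" are said of these compounds alone.

Compound 1, `CC1=C(CCc2nnn[nH]2)c2ccccc2/C1=C\c1ccc(C(C)(C)C)cc1`, and compound 3, `CC1=C(Cc2nnn[nH]2)c2ccccc2/C1=C\c1ccc(C(C)(C)C)cc1`, share one core and differ only in one place, (1H-tetrazol-5-yl in place of (1H-tetrazol-5-yl)methyl on a saturated chain carbon bound to a double-bonded ring carbon). In a functional assay on MCF7 cells (Homo sapiens) for inhibition, read by MTT assay, with a stated time of 48 h (on this read-out higher numbers stand for weaker inhibition and lower numbers for stronger inhibition), compound 1 gives 31100 nM, and in the same setting compound 3 gives 38400 nM; the step is a 1.2-fold higher number from compound 1 to compound 3 (0.09 log units; within the scatter). Compound 2, `CC1=C(CCc2nnn[nH]2)c2ccccc2/C1=C\c1ccccc1C(F)(F)F`, was run in this assay but no single number is reported for it, so its result is "not determined" (no result reported). The difference between the core of compound 1 and the core of compound 2 is not broken down here. Compound 4, `CC1=C(Cc2nnn[nH]2)c2ccccc2/C1=C\c1ccccc1C(F)(F)F`, stands to compound 2 as compound 3 stands to compound 1: the change is 1H-tetrazol-5-yl in place of (1H-tetrazol-5-yl)methyl on a saturated chain carbon bound to a double-bonded ring carbon, the same kind of change, at the same place. Because the step of a 1.2-fold higher number from compound 1 to compound 3 (0.09 log units; within the scatter) lies within the scatter, the corresponding change on the core of compound 2 is expected to move the number little as well. With no number for compound 2 to anchor it, the expectation for compound 4 in this assay rests only on compound 1 and compound 3, and compound 4 is estimated at 35000 nM, between 8000 nM and 150000 nM.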

Compound 4, half-maximal inhibitory concentration: 62300 nM
The estimate for compound 4 lay 1.8-fold (0.25 log units) below the measured number; the measured number falls inside the stated range.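

In this assay no new step can be read: compound 4 gives 62300 nM but compound 2 has no reported number to set it against. The compounds shown leave open whether the change from 2-(1H-tetrazol-5-yl)ethyl to (1H-tetrazol-5-yl)methyl moves the number on the core of compound 2. Nothing shown here offers an explanation of this result.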